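Putting 4-methylphenyl in place of 3-bromophenyl on an oxygen

The source may hold more compounds than are shown below. What is called first, only, known or untested is meant among the compounds shown, and "the series" means these compounds.

In a functional assay on MCF7 cells (Homo sapiens) for antiproliferative activity, read by MTT assay, with a stated time of 72 h (on this read-out higher numbers stand for weaker inhibition and lower numbers for stronger inhibition), compound 1 `O=S(=O)(Oc1ccccc1C(F)(F)F)C1CC2OC1C(c1ccc(/C=C/c3cc(O)cc(O)c3)cc1)=C2c1ccc(O)cc1` gives 18300 nM and compound 2 `O=S(=O)(Oc1cccc(Br)c1)C1CC2OC1C(c1ccc(/C=C/c3cc(O)cc(O)c3)cc1)=C2c1ccc(O)cc1` gives 19800 nM. Among the measured compounds shown here, these are the only two numbers so far, and they lie within the scatter of each other, so compound 2 stands level with compound 1. Compound 3 `Cc1ccc(OS(=O)(=O)C2CC3OC2C(c2ccc(/C=C/c4cc(O)cc(O)c4)cc2)=C3c2ccc(O)cc2)cc1` keeps the shared core and carries 4-methylphenyl in place of 3-bromophenyl on an oxygen. For the measured compounds named here, the only measured step that bears on this change is a 1.1-fold higher number from compound 1 to compound 2 (0.03 log units; within the scatter), which puts 3-bromophenyl in place of 2-(trifluoromethyl)phenyl on the same oxygen and lies within the scatter. With that single step as a guide, no change beyond the scatter is expected in this assay. The expected step is a 1.0-fold lower number from compound 2 to compound 3 (0.02 log units; within the scatter). For compound 3 the estimate is 19000 nM, with an expected range from 9000 nM to 40000 nM.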

Compound 3, half-maximal inhibitory concentration: 9200 nM
For compound 3 the middle estimate is 2.1-fold (0.31 log units) above the measured one, and the stated range covers the measured number.
By their numbers in this assay, from the lowest: compounds 3, 1 and 2 (each within the scatter of the next, the first and the last beyond it).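

In this assay, the aryl group on the oxygen whose other neighbour is the sulfonyl sulfur can shift the number: the change to 4-methylphenyl gives a 2.2-fold lower number from compound 2 to compound 3 (0.33 log units; beyond the scatter) and so passes beyond the scatter, which the step between the two earlier compounds did not do. Against the 2-(trifluoromethyl)phenyl group the same entering group gives a 2.0-fold lower number from compound 1 to compound 3 (0.30 log units; within the scatter) and stays within the scatter, so the effect remains modest and is seen against 3-bromophenyl only. No measurement given here explains this difference.

The 3-bromophenyl and 4-methylphenyl groups differ in both substituent and ring position, so the compounds shown cannot tell which of the two accounts for the step. Going by these compounds, how an amine or a carboxylic acid on this phenyl ring, or a longer alkyl chain in its place, would read also remains open.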